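The source may report more compounds than this note shows. Statements on the series, on what has been measured and on what is new or still open speak of the compounds shown alone.

Compound 1 `O=C(O)c1cncc(-c2ccc(N3CCC(Oc4ccccc4C(F)(F)F)CC3)nn2)c1` gives 129 nM in an assay on isolated protein for inhibition of acyl-CoA desaturase 1 (Rattus norvegicus); on this read-out lower numbers stand for stronger inhibition and higher numbers for weaker inhibition.
Compound 2 `O=C(O)c1cncc(-c2ccc(N3CCC(Oc4ccccc4Cl)CC3)nn2)c1` gives 166 nM in this assay.
Compound 3 `O=C(O)c1cncc(-c2ccc(N3CCC(Oc4ccccc4Br)CC3)nn2)c1` gives 47 nM in this assay.

Compound 3 stands lowest of the three: the step of a 2.7-fold lower number from compound 1 to compound 3 (0.44 log units; beyond the scatter) and the step of a 3.5-fold lower number from compound 2 to compound 3 (0.55 log units; beyond the scatter) both lie beyond the scatter, whereas a 1.3-fold higher number from compound 1 to compound 2 (0.11 log units; within the scatter) stays within it. Compound 4 `O=C(O)c1cncc(-c2ccc(N3CCC(Oc4ccccc4I)CC3)nn2)c1` carries the change (iodo in place of bromo on an aromatic carbon). Among the compounds with values here, the steps that bear on it are the two into compound 3, in which bromo replaced trifluoromethyl or chloro and the number fell by a modest amount each time. Within the data shown here, no measured step covers the move from bromo to iodo itself, so the expectation for compound 4 in this assay is a number near that of compound 3 or a little lower, and not a rise beyond the scatter. Compound 4 is therefore estimated at 35 nM, with a range from 15 nM to 90 nM, which amounts to an expected step of a 1.3-fold lower number from compound 3 to compound 4 (0.13 log units; within the scatter).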

Compound 4, half-maximal inhibitory concentration: 27 nM
Compound 4: the middle estimate sits 1.3-fold (0.11 log units) above what was measured, and the stated range covers the measured number.
By their numbers in this assay, from the lowest: compounds 4 and 3 (each within the scatter of the next); then compounds 1 and 2 (each within the scatter of the next).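

In this assay, iodo on the 2-iodophenoxy group stays level with bromo (a 1.7-fold lower number from compound 3 to compound 4 (0.24 log units; within the scatter)). Iodo also reads clearly lower than the other two groups (a 6.1-fold lower number from compound 2 to compound 4 (0.79 log units; beyond the scatter) and a 4.8-fold lower number from compound 1 to compound 4 (0.68 log units; beyond the scatter)), so the advantage that bromo showed over chloro and trifluoromethyl carries over to iodo. No measurement at hand explains these steps. On these data alone, how a methoxy group or an amine in place of iodo would read stays open, as does whether the same order of groups holds on a core without the carboxylic acid.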